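The compounds below may be only part of what the source reports. "The series", "measured", "known", "first", "only" and "open" are said of these compounds alone.

Measured compounds in the series:
compound 1 `CC(C)(C)c1ccc(CNC(=O)NCCCCl)cc1`
compound 2 `O=C(CCCCl)Nc1ccc(I)cc1`
compound 3 `CC(C)(C)c1ccc(NC(=O)CCCCl)cc1`

In a functional assay on M21 cells (Homo sapiens) for antiproliferative activity, with a stated time of 48 h (a higher number here means a weaker inhibitor, a lower number a stronger inhibitor), compound 1 gives 11000 nM. Compound 2 reports only a limit of this assay, > 100000 nM. Compound 3 also reports only a limit, > 100000 nM. Within the data shown here, compound 1 is thus the only compound with a number; the other two sit at the limit of > 100000 nM in this assay, at which 2 of the 3 values shown sit. The step that the two limits leave unreadable from compound 2 to compound 3 cannot be read for that reason, and no step to compound 1 is readable either.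

Compound 4 `CC(C)(C)c1ccc(CNC(=O)CCCCl)cc1` is the next compound for this assay. It differs from compound 1 by 3-chloropropyl in place of (3-chloropropyl)amino on a carbonyl carbon. Among the measured compounds shown here, no measured step covers this change directly. Compound 2 and compound 3 carry the same 3-chloropropyl on the carbonyl that enters in compound 4, and both stand at the limit of > 100000 nM in this assay, at which 2 of the 3 values shown sit, which points toward a weaker inhibitor but fixes no size. The step of a 3.2-fold higher number from compound 1 to compound 4 (0.50 log units; beyond the scatter) is therefore estimated as a weakening, its extent uncertain. Compound 4 is expected near 35000 nM, with a range from 8000 nM to 150000 nM.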

Compound 4, half-maximal inhibitory concentration: 69000 nM
Compound 4: middle estimate off by 2.0-fold (0.29 log units), on the low side; low and high end bracket the measured number.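

In this assay, among these compounds, 3-chloropropyl in place of (3-chloropropyl)amino on a carbonyl carbon gives the only readable step (a 6.3-fold higher number from compound 1 to compound 4 (0.80 log units; beyond the scatter)). Compound 3 carries the same 3-chloropropyl on its carbonyl and reports only a limit of the assay (> 100000 nM). Compound 4 keeps a number, so 3-chloropropyl on the carbonyl does not by itself put a compound at the limit, although every step to a compound at the limit cannot be read.

As far as these compounds go, with a single readable pair, it stays open whether this step would hold on another core. From the compounds shown here alone, the effect of a longer chain in place of 3-chloropropyl, or of a hydroxyl or an amine in place of the chlorine, also stays open in this assay.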